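The compounds below may be only part of what the source reports. "The series", "measured", "known", "first", "only" and "open" are said of these compounds alone.

Compound 1 `Cc1ccc(NC(=S)NC(=O)c2ccc(OCc3ccc(Cl)c(Cl)c3)cc2)cc1-c1nc2ccccc2[nH]1` and compound 3 `O=C(NC(=S)Nc1ccc(Cl)c(-c2nc3ccccc3[nH]2)c1)c1ccc(OCc2ccc(Cl)c(Cl)c2)cc1` share a core that differs in one spot, namely (chloro in place of methyl on an aromatic carbon). In a functional assay on HT-29 cells (Homo sapiens) for inhibition, read by MTT assay, with a stated time of 48 h (on this read-out higher numbers stand for weaker inhibition and lower numbers for stronger inhibition), compound 1 gives 6270 nM, and compound 3 gives 4930 nM, so that a 1.3-fold lower number from compound 1 to compound 3 (0.10 log units; within the scatter). Compound 2 `Cc1ccc(NC(=S)NC(=O)c2ccc(OCc3ccc(Cl)cc3Cl)cc2)cc1-c1nc2ccccc2[nH]1` arises from compound 1 through (2,4-dichlorophenyl in place of 3,4-dichlorophenyl on a saturated chain carbon bound to an oxygen on an aromatic ring); in this assay compound 2 gives 11600 nM, which makes a 1.9-fold higher number from compound 1 to compound 2 (0.27 log units; within the scatter). Compound 4 `O=C(NC(=S)Nc1ccc(Cl)c(-c2nc3ccccc3[nH]2)c1)c1ccc(OCc2ccc(Cl)cc2Cl)cc1` carries the same change on the core of compound 3, (2,4-dichlorophenyl in place of 3,4-dichlorophenyl on a saturated chain carbon bound to an oxygen on an aromatic ring), at a place described in the same words. For compound 4 the step is expected to be a 1.9-fold higher number from compound 3 to compound 4 (0.28 log units; within the scatter). This expectation rests on a 1.9-fold higher number from compound 1 to compound 2 (0.27 log units; within the scatter) and on compound 3 at 4930 nM. Compound 4 is therefore estimated at 9400 nM, with a likely range from 4000 nM to 22000 nM.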

Compound 4, half-maximal inhibitory concentration: 6080 nM
The estimate for compound 4 lay 1.5-fold (0.19 log units) above the measured number; low and high end bracket the measured number.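

In this assay, 2,4-dichlorophenyl in place of 3,4-dichlorophenyl gives a 1.2-fold higher number from compound 3 to compound 4 (0.09 log units; within the scatter), and this step agrees with the one on the other core: the same change on two cores in this assay, a 1.9-fold higher number (0.27 log units; within the scatter) from compound 1 to compound 2 and a 1.2-fold higher number (0.09 log units; within the scatter) from compound 3 to compound 4, 1.5-fold (0.18 log units) apart, within the scatter of two such steps

Chloro in place of methyl on an aromatic carbon gives a 1.9-fold lower number from compound 2 to compound 4 (0.28 log units; within the scatter), and this step also agrees with its earlier counterpart: the same change on two cores in this assay, a 1.3-fold lower number (0.10 log units; within the scatter) from compound 1 to compound 3 and a 1.9-fold lower number (0.28 log units; within the scatter) from compound 2 to compound 4, 1.5-fold (0.18 log units) apart, within the scatter of two such steps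

Both changes therefore carry from one core to the other without a detectable difference, but as each single step lies within the scatter, these four compounds do not show that either change has a real effect of its own, nor how it would behave on other cores.

The compounds shown leave open whether this agreement would hold with a plain phenyl in place of the dichlorophenyl, or with a bromo or methoxy group in place of the chloro on the aromatic carbon.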